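Trifluoromethyl for phenyl on the amino-bearing five-membered ring

The source may hold more compounds than are shown below. What is called first, only, known or untested is meant among the compounds shown, and "the series" means these compounds.

Measured so far:
compound 1 `C/C(=N/O)c1ccc(NC(=O)Cn2nc(-c3ccccc3)nc2N)cc1` — 15.4%
compound 2 `c1ccc(-c2nc3sc(-c4ccccc4)cn3n2)cc1` — 53%

In a functional assay on UO-31 cells (Homo sapiens) for inhibition, read by sulforhodamine B assay, with a stated time of 48 h, tested at 10 uM (a lower number here means less inhibition of growth, a higher number more inhibition of growth at the concentration tested), compound 1 gives 15.4%, the lower of the two numbers at hand. Compound 2, a compound of a different build, gives 53% in this assay; the gap between the two values lies beyond the scatter of repeated measurements, but the two structures differ in more than one place, so the gap cannot be tied to any single change.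

Compound 3 `C/C(=N/O)c1ccc(NC(=O)Cn2nc(C(F)(F)F)nc2N)cc1` is not yet measured. It differs from compound 1 in one place: trifluoromethyl in place of phenyl on an aromatic carbon. The change sits on the aromatic carbon between two ring nitrogen atoms of the five-membered aromatic ring with 3 nitrogen, with the amino group kept.

Going by the values given here, with no single-change step among the measured compounds, the size of this step is open. Given the low growth inhibition of compound 1 in this assay, the step from compound 1 to compound 3 is expected to be small, within the scatter, as a number 3.4 percentage points lower from compound 1 to compound 3 (within the scatter). Compound 3 is expected to give about 12% in this assay, with a range from 0% to 30%.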

Compound 3, percent growth inhibition at one concentration: 15.1%
The estimate for compound 3 lay 3.1 percentage points below the measured number; the range from low to high includes it.
By their numbers in this assay, from the lowest: compounds 3 and 1 (each within the scatter of the next); then compound 2.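

In this assay, going by these compounds alone, the first single-change step reads a number 0.3 percentage points lower from compound 1 to compound 3 (within the scatter), so trifluoromethyl in place of phenyl on this aromatic carbon, with the amino group kept, leaves the read-out within the scatter. At this place between two ring nitrogen atoms, the six-membered aromatic ring of compound 1 is therefore not required for the level of growth inhibition seen at the concentration tested, and a group with no ring serves equally in this read-out. No measurement at hand bears on the reason for this result.

As far as these compounds go, whether a carboxylic acid, an amine or a longer alkyl chain on this carbon would also leave the read-out unmoved remains open, as does the effect of replacing the amino group or the oxime on the phenyl ring of the anilide. Steps from compound 2 cannot be read, since it differs from compound 1 and compound 3 in more than one place, so nothing shown links any single feature to its higher number.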